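The source may hold more compounds than are shown below. What is called first, only, known or untested is meant among the compounds shown, and "the series" means these compounds.

Measured so far in a functional assay on the whole organism (Tail) for activation, with Mus musculus as the target, with a stated time of 1 min; a higher number here means that more compound is needed for the effect, a lower number that less compound is needed:
Compound 1 `O=C1CN(/N=C/c2ccc(-c3cccc(C(F)(F)F)c3)o2)C(=O)N1` gives 184 mg/kg.
Compound 2 `O=C1NC(=O)N(/N=C/c2ccc(-c3ccc([N+](=O)[O-])cc3)o2)C1O` gives only a limit of the assay, > 1000 mg/kg.
Compound 3 `CC(=O)Nc1ccc(-c2ccc(/C=N/N3C(=O)NC(=O)C3O)o2)cc1` likewise gives only a limit of the assay, > 1000 mg/kg.

Going by the values given here, compound 3 therefore stands at the limit of > 1000 mg/kg in this assay, at which 2 of the 3 values shown sit, and the single measured step, from compound 2 to compound 3 a step that the two limits leave unreadable from compound 2 to compound 3, cannot be read. Compound 4 `Nc1ccc(-c2ccc(/C=N/N3C(=O)NC(=O)C3O)o2)cc1` differs from compound 3 by hydrogen in place of acetyl on a nitrogen on an aromatic ring. Among the compounds with values here, no measured step covers this change, and the one step available, a step that the two limits leave unreadable from compound 2 to compound 3, gives no size to lean on. With no evidence of a shift in this assay, compound 4 is expected to remain near the limit; the expected step of a number no higher from compound 3 to compound 4 (the limit leaves the size open) is none beyond the scatter. Compound 4 is estimated at 1000 mg/kg, within a range of 300 mg/kg to 3000 mg/kg.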

Compound 4, dose for half-maximal effect: > 1000 mg/kg
Compound 4: no number, only a limit; the forecaster's own chance of this, stated with the estimate: 70%; the middle value sits exactly at the limit.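

In this assay compound 4 gives only a limit, > 1000 mg/kg, and its steps from compound 2 and from compound 3 cannot be read. The compounds shown leave open whether nitro, acetamido and amino differ at all in this assay.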